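Aryl versus alkyl at the triple-bonded carbon

The source may hold more compounds than are shown below. What is called first, only, known or untested is meant among the compounds shown, and "the series" means these compounds.

Compound 2 `CCCCC#Cc1cn(C/C=C\CN2C(=O)c3ccccc3C2=O)c(=O)[nH]c1=O` gives 100000 nM in a functional assay on CCRF-CEM cells (Homo sapiens) for antiproliferative activity, read by MTT assay, with a stated time of 3 days; on this read-out lower numbers stand for stronger inhibition and higher numbers for weaker inhibition. Compound 1 `CCCCCc1ccc(C#Cc2cn(C/C=C\CN3C(=O)c4ccccc4C3=O)c(=O)[nH]c2=O)cc1` gives 102000 nM in this assay. Within the data shown here, the two numbers lie within the scatter of each other, so compound 2 cannot be placed above or below compound 1 on this read-out; the single measured step is a 1.0-fold lower number from compound 1 to compound 2 (0.01 log units; within the scatter), flat.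

Compound 3 `CCCCc1ccc(C#Cc2cn(C/C=C\CN3C(=O)c4ccccc4C3=O)c(=O)[nH]c2=O)cc1` differs from compound 2 in one place: 4-butylphenyl in place of butyl on a triple-bonded carbon. Among the measured compounds shown here, the only measured step that bears on this change is the one from butyl to 4-pentylphenyl, which did not move the read-out beyond the scatter. Because that step was a 1.0-fold lower number from compound 1 to compound 2 (0.01 log units; within the scatter), no step beyond the scatter is expected for compound 3, and the expected step is no change at the digits printed from compound 2 to compound 3 (within the scatter). Compound 3 is therefore estimated at 100000 nM, with a range from 50000 nM to 200000 nM; the measured numbers sit where the assay may report only a limit.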

Compound 3, half-maximal inhibitory concentration: 23000 nM
Compound 3: middle estimate off by 4.3-fold (0.64 log units), on the high side; the measured number lies below the stated range.
By their numbers in this assay, from the lowest: compound 3; then compounds 2 and 1 (each within the scatter of the next).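

At the triple-bonded carbon, the exchange of alkyl for aryl is not flat in every case: in this assay there is a 4.3-fold lower number from compound 2 to compound 3 (0.64 log units; beyond the scatter) with 4-butylphenyl in place of butyl. The length of the chain on the ring also counts at this position, with a 4.4-fold lower number from compound 1 to compound 3 (0.65 log units; beyond the scatter) when hydrogen replaces methyl on a saturated chain carbon, four bonds along the chain from an aromatic carbon. The flat step between compounds 1 and 2 therefore did not show that this position is indifferent to its substituent.

Still open, on these data alone, is whether a propyl or ethyl chain on the phenyl ring, or a phenyl ring with no chain at all, would give a lower number than compound 3. A terminal amine or carboxylic acid on the chain is equally untested here. Nothing on hand explains either step.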